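Chloro substitution on the phenyl ring of compound 1

The compounds below may be only part of what the source reports. "The series", "measured", "known", "first", "only" and "open" are said of these compounds alone.

Compound 1 `Cc1ccccc1N(C)C(=O)c1ccc(-c2ccc(OS(N)(=O)=O)cc2)o1`: 28 nM
Compound 2 `Cc1cc(-c2ccc(C(=O)N(C)c3ccccc3C)o2)ccc1OS(N)(=O)=O`: 570 nM
Compound 3 `Cc1ccccc1N(C)C(=O)c1ccc(-c2ccc(OS(N)(=O)=O)c(F)c2)o1`: 17 nM

These three compounds share one core and were tested in an assay on T47D cells for inhibition of Steryl-sulfatase (Homo sapiens), read by HPLC, with a stated time of 24 h; a higher number here means a weaker inhibitor, a lower number a stronger inhibitor. Compound 1 gives 28 nM, the second highest of the three numbers; its nearest neighbour is compound 3, which gives 17 nM, and the furthest is compound 2, which gives 570 nM.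

Compound 4 `Cc1ccccc1N(C)C(=O)c1ccc(-c2ccc(OS(N)(=O)=O)cc2Cl)o1` is not yet measured. It differs from compound 1 by chloro in place of hydrogen on an aromatic carbon.

Among the compounds with values here, two measured steps bear on this change, both on the same ring. A methyl in place of hydrogen gave a 20-fold higher number from compound 1 to compound 2 (1.31 log units; beyond the scatter), a large loss. A fluoro in place of hydrogen gave a 1.6-fold lower number from compound 1 to compound 3 (0.22 log units; within the scatter), which stays within the scatter. The contrast between these two is a 34-fold lower number from compound 2 to compound 3 (1.53 log units; beyond the scatter). The chloro of compound 4 sits at a different place on the ring than either of those groups, so neither step transfers directly. Taken together they suggest a halogen is tolerated while a larger carbon group is not; chloro lies between the two in size.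

Compound 4 is therefore expected to show a modest change, a 2.1-fold higher number from compound 1 to compound 4 (0.33 log units; beyond the scatter), with an estimated value of 60 nM (range 15 nM to 250 nM).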

Compound 4, half-maximal inhibitory concentration: 27 nM
Compound 4: the middle estimate sits 2.2-fold (0.35 log units) above what was measured; low and high end bracket the measured number.
By their numbers in this assay, from the lowest: compounds 3, 4 and 1 (each within the scatter of the next); then compound 2.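

In this assay, chloro in place of hydrogen, ortho to a large group and meta to a sulfamoyloxy group, gives a 1.0-fold lower number from compound 1 to compound 4 (0.02 log units; within the scatter), so at this place on the ring a chlorine atom leaves the number within the usual scatter of the value for the unsubstituted compound. The methyl of compound 2 and the fluoro of compound 3 sit elsewhere on the ring, so those earlier compounds could say nothing directly about this position, and compound 4 now shows that it accepts at least one substituent without a change that can be told from scatter. Nothing shown here offers a measured explanation for this result.

From the compounds shown here alone, one chloro cannot show how much this position will accept, so it remains open whether a methoxy group, an amine or a carboxylic acid at the same place would also leave the number within the scatter. Going by these compounds, it is also open how a chloro would behave at the place held by the fluoro of compound 3, which would separate the effect of the group from the effect of its place on the ring.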